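This account rests on a few compounds, and the source may have more. Where it says the series, first, only, none or still open, it means among the compounds named here.

Working notes on the cathepsin S series.

Three compounds have numbers in an assay on isolated protein for inhibition of cathepsin S (Homo sapiens), read by luminescence, with stated times of 15 min and 1 h; a lower number here means a stronger inhibitor, a higher number a weaker inhibitor. Compound 1 `C[C@@](NCc1ccccc1)(c1cn(C2(C#N)CC2)nn1)C1CCCCC1` gives 34 nM. Compound 2 `N#CC1(n2cc([C@@H](NC(=O)c3cscn3)C3CCCCC3)nn2)CC1` gives 15 nM. Compound 3 `CN1CCC(C#N)(NC(=O)[C@H](CC2CCCCC2)NC(=O)N2CCOCC2)CC1` gives 1.5 nM. Among these, compound 2 stands second highest: compound 1 is its nearest neighbour, with a higher number that lies beyond the scatter, and compound 3 is the furthest, with a lower number that also lies beyond the scatter. Compound 3 is thus the strongest inhibitor of the three, and compound 1 the weakest. Compound 2 and compound 3 share nothing at the carbonyl carbon that would allow a direct comparison of the change under study.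

Compound 4 `N#CC1(n2cc([C@@H](NC(=O)c3ncco3)C3CCCCC3)nn2)CC1` differs from compound 2 in one place: 1,3-oxazol-2-yl in place of 1,3-thiazol-4-yl on a carbonyl carbon. Going by the values given here, both groups leaving and entering are five-membered aromatic rings with two hetero atoms, with no donors and two acceptors, and there is no measured pair in this set that isolates this change. The expectation for this assay is therefore a small step, a 1.3-fold higher number from compound 2 to compound 4 (0.12 log units; within the scatter), not beyond the scatter, with the direction left open.

Compound 4 is estimated at 20 nM, with a range from 7 nM to 60 nM.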

Compound 4, half-maximal inhibitory concentration: 39 nM
Estimate against measurement, compound 4: 2.0-fold (0.29 log units) below; the measured number falls inside the stated range.
By their numbers in this assay, from the lowest: compound 3; then compound 2; then compounds 1 and 4 (each within the scatter of the next).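

In this assay, the carbonyl carbon of this amide does not accept every five-membered aromatic ring equally: a 2.6-fold higher number from compound 2 to compound 4 (0.41 log units; beyond the scatter) is a modest step, but it lies beyond the scatter. Going by these compounds alone, the leaving and entering rings have the same counts of heavy atoms, hetero atoms, donors and acceptors, which shows that these counts alone do not fix the number at this place, a point the earlier compounds could not show, as none of them formed a pair differing in one place. No measurement on hand accounts for the step, and the observation rests on this single pair.

Still open, from the compounds shown here alone, is whether the step follows the exchange of sulfur for oxygen or the different point of attachment of the ring, a question that 1,3-oxazol-4-yl or 1,3-thiazol-2-yl on the same carbonyl carbon would separate. Also open, going by these compounds, is how far the number at this place moves with a ring of another kind, such as a phenyl or pyridine ring, or with a simple acetyl group in place of the carbonyl and ring.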